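Methyl for fluoro on the carbamate aryl ring: compound 3

The compounds below may be only part of what the source reports. "The series", "measured", "known", "first", "only" and "open" are said of these compounds alone.

Compound 2, `N#C[Se]c1ccc(NC(=O)Oc2ccc(F)cc2)cc1`, gives 65700 nM in a functional assay on MCF7 cells (Homo sapiens) for cytotoxicity, read by MTT assay, with a stated time of 72 h; on this read-out higher numbers stand for lower toxicity in this test and lower numbers for higher toxicity in this test. Among the compounds with values here, its only measured neighbour is compound 1, `COc1ccc(OC(=O)Nc2ccc([Se]C#N)cc2)cc1`, which in this assay gives 74100 nM; the step of a 1.1-fold lower number from compound 1 to compound 2 (0.05 log units; within the scatter) lies within the scatter, so the two stand level. Compound 3, `Cc1ccc(OC(=O)Nc2ccc([Se]C#N)cc2)cc1`, differs from compound 2 by methyl in place of fluoro on an aromatic carbon. Within the data shown here, the single comparable step, from compound 1 to compound 2, exchanged one small group at this same position without a change beyond the scatter, so for compound 3 the expected step is a 1.0-fold lower number from compound 2 to compound 3 (0.00 log units; within the scatter), no direction beyond the scatter. Compound 3 is estimated at 65000 nM, with a range from 30000 nM to 140000 nM.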

Compound 3, concentration lethal to 50% of the cells: 69800 nM
Compound 3: the middle estimate sits 1.1-fold (0.03 log units) below what was measured, within the range that was stated.
By their numbers in this assay, from the lowest: compounds 2, 3 and 1 (each within the scatter of the next).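

With methyl, this position para to a large group has now carried fluoro, methoxy and methyl, and in this assay all three stand level: the exchange for fluoro (a 1.1-fold higher number from compound 2 to compound 3 (0.03 log units; within the scatter)) and the exchange for methoxy (a 1.1-fold lower number from compound 1 to compound 3 (0.03 log units; within the scatter)) both stay within the scatter. Replacing fluoro with methyl, one heavy atom for another, therefore leaves the number as unmoved as the earlier exchange did. No measurement at hand accounts for this. Going by these compounds, whether an amine, a carboxylic acid or a longer chain at this position would move the number beyond the scatter remains open.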